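The source may report more compounds than this note shows. Statements on the series, on what has been measured and on what is new or still open speak of the compounds shown alone.

Compounds with measured values:
compound 1, `CN(C)CCN(CCN(C)C)c1ccc(C(=O)N2CCc3ccc(OS(N)(=O)=O)cc3C2)cc1`: 15.9%
compound 2, `NS(=O)(=O)Oc1ccc2c(c1)CN(C(=O)c1ccc(N3CCN(Cc4ccccc4)CC3)cc1)CC2`: 75.8%
compound 3, `CCN(Cc1ccncc1)c1cccc(C(=O)N2CCc3ccc(OS(N)(=O)=O)cc3C2)c1`: 52.8%

In an assay on HEK293 cells for inhibition of Steryl-sulfatase (Homo sapiens), tested at 1 uM (on this read-out higher numbers stand for a stronger effect at the one concentration tested and lower numbers for a weaker effect), compound 1 stands lowest of the three numbers. The nearest of the others is compound 3, whose value in this assay lies beyond the scatter above that of compound 1, and the furthest is compound 2, whose value in this assay lies still further above. Among the compounds with values here, no two of the measured compounds differ in a single place, so no measured single step is at hand, and the three numbers are read only as they stand.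

Compound 4, `CCN(Cc1ccc(F)cc1)c1ccc(C(=O)N2CCc3ccc(OS(N)(=O)=O)cc3C2)cc1`, has not yet been measured. It differs from compound 1 in one place: ethyl(4-fluorobenzyl)amino in place of bis(2-(dimethylamino)ethyl)amino on an aromatic carbon

The step from compound 1 to compound 4 is expected to be upward and beyond the scatter, estimated as a number 39.1 percentage points higher from compound 1 to compound 4 (beyond the scatter), because compound 3 gives 52.8% with a group of the same kind on the same aromatic carbon, and compound 1 with bis(2-(dimethylamino)ethyl)amino sits far below. Compound 4 is therefore expected to give about 55% in this assay, most likely between 30% and 78%.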

Compound 4, a percentage reported as inhibition, at one concentration (the size of the read-out at that concentration, not a potency): 91.2%
Estimate against measurement, compound 4: 36.2 percentage points below; measured number above the stated range.
By their numbers in this assay, from the lowest: compound 1; then compound 3; then compound 2; then compound 4.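

In this assay, within the data shown here, ethyl(4-fluorobenzyl)amino in place of bis(2-(dimethylamino)ethyl)amino on this aromatic carbon gives a number 75.3 percentage points higher from compound 1 to compound 4 (beyond the scatter), the first single change that can be read in this set, and it shows that the group at this place alone can carry the read-out from near the bottom of the series to its top. The two groups match in size, with 11 heavy atoms each and no hydrogen-bond donor, so the large step comes with a change in the kind of atoms and not in their count: the entering group holds a six-membered aromatic ring of carbon only and a fluorine, and it has fewer nitrogens and hydrogen-bond acceptors. No measured evidence bears on why the step is so large.

The compounds shown leave open which part of the entering group matters, since a plain benzyl in place of 4-fluorobenzyl, or a methyl in place of the ethyl, would separate the contributions of its parts. They also leave open whether a single 2-(dimethylamino)ethyl arm paired with the 4-fluorobenzyl would keep the number of compound 4 at 91.2%.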